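A few compounds are considered here, and "the series" means these few. Any claim that something is new, unique, unknown or untested is made for them only; others in the source may bear on it.

Measured so far in an assay on isolated protein for binding affinity to leukotriene B4 receptor 1 (Homo sapiens), tested at 1 uM; on this read-out lower numbers stand for less inhibition and higher numbers for more inhibition at the one concentration tested (going by the name of the read-out):
compound 1 `CCc1cc(C(C)=O)c(O)cc1OCCCCCC(C)(C)C(=O)O` gives 73%;
compound 2 `CCc1cc(C(C)=O)c(O)cc1OCCCCCn1cncn1` gives 30%.

Among the compounds with values here, compound 2 stands lowest of the two; its nearest neighbour is compound 1, and the single measured step, a number 43 percentage points lower from compound 1 to compound 2 (beyond the scatter), is large. Compound 3 `CCc1cc(C(C)=O)c(O)cc1OCCCCCCC(=O)N(C)C` differs from compound 2 by (dimethylcarbamoyl)methyl in place of 1H-1,2,4-triazol-1-yl on a saturated chain carbon, five bonds along the chain from an oxygen on an aromatic ring. Within the data shown here, the only step available bears on it indirectly: it shows that exchanging the acid of compound 1 for the triazole cost much, but no step compares the triazole with an amide. Both compound 2 and compound 3 lack the acid, so no step beyond the scatter is expected; the estimate for compound 3 is 30%, within 10% to 55%, meaning an expected no change at the digits printed from compound 2 to compound 3 (within the scatter).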

Compound 3, a percentage reported as inhibition, at one concentration (the size of the read-out at that concentration, not a potency): 61%
For compound 3 the middle estimate is 31 percentage points below the measured one; measured number outside the range, above it.
By their numbers in this assay, from the lowest: compound 2; then compound 3; then compound 1.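

Without a carboxylic acid in either compound, the group on this saturated chain carbon still matters in this assay: the change from 1H-1,2,4-triazol-1-yl to (dimethylcarbamoyl)methyl gives a number 31 percentage points higher from compound 2 to compound 3 (beyond the scatter) and so recovers much of the earlier loss. Against the acid-bearing group, the amide shows a number 12 percentage points lower from compound 1 to compound 3 (beyond the scatter), so a carboxylic acid is not the only group here that gives a high number. No supporting data explain why these groups differ.

Still open, going by these compounds, is whether a primary amide or a methyl ester would hold this level. A shorter or longer chain carrying the dimethylamide also remains to be placed in the series.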